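The source may report more compounds than this note shows. Statements on the series, on what has been measured and on what is new or still open speak of the compounds shown alone.

In an assay on brain for binding affinity to Voltage-gated L-type calcium channel (Rattus norvegicus) (on this read-out lower numbers stand for stronger inhibition and higher numbers for weaker inhibition), three compounds have been measured:

Compound 1, `CCOC(=O)[C@@H]1/C(=C/C(=O)c2ccncc2)N=C(C)/C(=C(/O)OCC)[C@H]1c1ccccc1C(F)(F)F`, gives 25.5 nM.
Compound 2, `CCOC(=O)[C@@H]1/C(=C/C(=O)c2ccc(F)cc2)N=C(C)/C(=C(/O)OCC)[C@H]1c1ccccc1C(F)(F)F`, gives 117 nM.
Compound 3, `CCOC(=O)[C@@H]1C(C2=C(O)c3ccccc3CC2)=NC(C)=C(C#N)[C@H]1c1ccccc1C(F)(F)F`, gives > 1000 nM, which is a limit of the assay and not a number.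

Compound 3 thus stands at the limit of > 1000 nM in this assay, at which 1 of the 3 values shown sits, and no number is known for it. Going by the values given here, the only measured step, a 4.6-fold higher number from compound 1 to compound 2 (0.66 log units; beyond the scatter), alters the group on the carbonyl carbon, a different place from the one changed here, so it does not bear on the present step. Compound 4, `CCOC(=O)C1=C(C)N=C(C2=C(O)c3ccccc3CC2)[C@@H](C(=O)OCC)[C@@H]1c1ccccc1C(F)(F)F`, differs from compound 3 by ethoxycarbonyl in place of cyano on a double-bonded ring carbon. Among the compounds with values here, compounds 1 and 2 carry ethoxycarbonyl at that place and give numbers, but they differ from compound 4 elsewhere as well, so no measured step supports the change directly. Compound 4 is expected to give 800 nM, between 150 nM and 5000 nM, which would mean an expected at least 1.2-fold lower number from compound 3 to compound 4 (0.09 log units; that floor lies within the scatter) of uncertain direction.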

Compound 4, half-maximal inhibitory concentration: > 1000 nM
Compound 4: no number, only a limit; the forecaster's own chance of this, stated with the estimate: 40%; middle value at least 1.2-fold (0.09 log units) from the limit.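

Compound 4 gives > 1000 nM in this assay and this is a limit, not a number. Compound 3 also stands at a limit, so the step from compound 3 to compound 4 cannot be read. The compounds shown leave open whether ethoxycarbonyl or cyano at this place gives the stronger inhibition.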